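The compounds below may be only part of what the source reports. "The series", "measured", "known", "first", "only" and "open" are said of these compounds alone.

Compound 1 `COc1cccc(CNCCCNc2ccnc3cc(Oc4ccc(Cl)cc4)ccc23)c1O`: 14500 nM
Compound 2 `COc1ccc(-c2ccc3c(NCCCNCc4ccco4)ccnc3c2)cc1`: 32000 nM

Both numbers come from a physicochemical assay for solubility, with a stated time of 18 h, at pH 7.4; on this read-out lower numbers stand for lower solubility and higher numbers for higher solubility. Of the two, compound 1 has the lower number, and its gap to compound 2 lies beyond the usual scatter. Compound 3 `COc1cccc(CNCCCNc2ccnc3cc(Cc4ccc(F)cc4)ccc23)c1O` has not yet been measured in this assay; it differs from compound 1 in one place: 4-fluorobenzyl in place of 4-chlorophenoxy on an aromatic carbon. No measured pair here shows a change of this kind, so nothing among these compounds tells its size. The expectation is a step no larger than the scatter, leaning slightly upward, with an expected move of a 1.2-fold higher number from compound 1 to compound 3 (0.09 log units; within the scatter). Compound 3 is therefore estimated at 18000 nM, within a range from 7000 nM to 45000 nM.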

Compound 3, solubility: 4200 nM
The estimate for compound 3 lay 4.3-fold (0.63 log units) above the measured number, outside the stated range (below it).
By their numbers in this assay, from the lowest: compound 3; then compound 1; then compound 2.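

In this assay this aromatic carbon of the shared core proves sensitive to the exchange: 4-fluorobenzyl in place of 4-chlorophenoxy gives a 3.5-fold lower number from compound 1 to compound 3 (0.54 log units; beyond the scatter) even though both groups carry one six-membered aromatic ring of carbon only and equal numbers of heavy atoms. The earlier compounds shown here offered no step of this kind at this position. No measurement at hand accounts for the step.

The exchange alters the atom joining the ring to the core and the halogen together, and the compounds shown do not separate the two. A 4-chlorobenzyl or 4-fluorophenoxy group at this carbon would tell them apart.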